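The source may report more compounds than this note shows. Statements on the series, on what has been measured and on what is new or still open speak of the compounds shown alone.

Working notes on the series. Three compounds of a shared core have numbers in an assay on cell membranes from brain for displacement of a labelled ligand from adenosine receptor A1 (Bos taurus); a lower number here means a stronger inhibitor, a higher number a weaker inhibitor. Compound 1 `Cn1c(=O)c2c(nnn2C2CCCCC2)n(C)c1=O` gives 23000 nM in this assay. Compound 2 `Cn1c(=O)c2nn(C3CC4CCC3C4)nc2n(C)c1=O` gives 31000 nM. Compounds 1 and 2 carry methyl groups where the next compound carries propyl groups; compound 3 `CCCn1c(=O)c2c(nnn2C2CCCC2)n(CCC)c1=O` gives 340 nM, the lowest of the three numbers, with both other values lying well beyond the scatter above it. Compound 4 `CCCn1c(=O)c2c(nnn2C2CCCCC2O)n(CCC)c1=O` is not yet measured; relative to compound 3 the change is 2-hydroxycyclohexyl in place of cyclopentyl on an aromatic nitrogen. Within the data shown here, no measured pair isolates this change, so its effect is unknown. A moderate loss is expected, a 2.9-fold higher number from compound 3 to compound 4 (0.47 log units; beyond the scatter), with a wide range. For compound 4 the estimate in this assay is 1000 nM, between 200 nM and 5000 nM.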

Compound 4, inhibition constant: 1800 nM
The estimate for compound 4 lay 1.8-fold (0.26 log units) below the measured number; the measured number falls inside the stated range.
By their numbers in this assay, from the lowest: compound 3; then compound 4; then compounds 1 and 2 (each within the scatter of the next).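

In this assay this aromatic nitrogen now has its first readable step, a 5.3-fold higher number from compound 3 to compound 4 (0.72 log units; beyond the scatter), for 2-hydroxycyclohexyl in place of cyclopentyl. The position therefore accepts a larger substituent carrying a hydrogen-bond donor and acceptor with only a modest loss. Nothing at hand explains the loss.
Still open, as far as these compounds go, is how much of the step belongs to the ring size and how much to the hydroxyl. A plain cyclohexyl or a 2-aminocyclohexyl on the same nitrogen, with the propyl groups kept, would bear on that question.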